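This account rests on a few compounds, and the source may have more. Where it says the series, first, only, none or still open, it means among the compounds named here.

Compound 1 `Cc1cccc(CN2CCN(C(=O)CN[C@H]3CCN(S(=O)(=O)Cc4ccccc4)C3)CC2)c1`: 11300 nM
Compound 2 `Cc1ccc(CN2CCN(C(=O)CN[C@H]3CCN(S(=O)(=O)Cc4ccccc4)C3)CC2)cc1`: 8200 nM
Compound 3 `O=C(CN[C@H]1CCN(S(=O)(=O)Cc2ccccc2)C1)N1CCN(Cc2ccc(Cl)cc2Cl)CC1`: 4300 nM

These three compounds share one core and differ only in the aromatic group carried on a saturated chain carbon bound to an amine nitrogen in a ring. In a functional assay on K562 cells (Homo sapiens) for cytotoxicity, read by MTT assay, with a stated time of 48 h (on this read-out higher numbers stand for weaker inhibition and lower numbers for stronger inhibition), compound 2 stands second highest of the three numbers; its nearest neighbour is compound 1, and the one furthest from it is compound 3.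

Compound 4 `COc1cccc(CN2CCN(C(=O)CN[C@H]3CCN(S(=O)(=O)Cc4ccccc4)C3)CC2)c1` has not yet been tested. Its difference from compound 2 is 3-methoxyphenyl in place of 4-methylphenyl on a saturated chain carbon bound to an amine nitrogen in a ring. Within the data shown here, three measured steps touch the same place: a 1.4-fold lower number from compound 1 to compound 2 (0.14 log units; within the scatter), a 1.9-fold lower number from compound 2 to compound 3 (0.28 log units; within the scatter) and a 2.6-fold lower number from compound 1 to compound 3 (0.42 log units; beyond the scatter). No measured compound carries a methoxy group, so its own effect is not shown; what is shown is that moving a methyl group around the ring left the number almost unchanged. The step to compound 4 is therefore expected to be small, a 1.2-fold higher number from compound 2 to compound 4 (0.09 log units; within the scatter), with no clear direction beyond the scatter. Compound 4 is estimated at 10000 nM, within a range from 4500 nM to 22000 nM.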

Compound 4, half-maximal inhibitory concentration: 60800 nM
For compound 4 the middle estimate is 6.1-fold (0.78 log units) below the measured one; the measured number lies above the stated range.
By their numbers in this assay, from the lowest: compounds 3, 2 and 1 (each within the scatter of the next, the first and the last beyond it); then compound 4.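

Replacing methyl with methoxy on an aromatic carbon is the narrowest change here, and in this assay it gives a 5.4-fold higher number from compound 1 to compound 4 (0.73 log units; beyond the scatter), so this position is far less forgiving than the methyl shift alone suggested. The wider swaps point the same way, with a 7.4-fold higher number from compound 2 to compound 4 (0.87 log units; beyond the scatter) and a 14-fold higher number from compound 3 to compound 4 (1.15 log units; beyond the scatter), which means that the aromatic group at this position can markedly weaken inhibition rather than leave it almost unchanged. No measurement at hand accounts for this jump.

As far as these compounds go, whether the higher number follows the oxygen of the methoxy group or some other part of the change stays open. Compounds carrying a hydroxy group, an amine or a fluorine atom in place of the methoxy group would help to settle that.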